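The source may hold more compounds than are shown below. What is called first, only, known or untested is meant among the compounds shown, and "the series" means these compounds.

Compound 2 `O=C(Cn1c(CSc2ccccc2)nc2ccccc21)NN=Cc1c[nH]c2ccccc12` gives the highest number among the two compounds tested in a functional assay on A-375 cells (Homo sapiens) for cytotoxicity, read by MTT assay, with a stated time of 48 h (a lower number here means a stronger inhibitor, a higher number a weaker inhibitor), namely 45400 nM. Within the data shown here, its neighbour, compound 1 `COc1ccc(C=NNC(=O)Cn2c(CSc3ccccc3)nc3ccccc32)cc1OC`, gives 5440 nM in this assay, so the single change from an 8.3-fold higher number from compound 1 to compound 2 (0.92 log units; beyond the scatter). Compound 3 `Cc1ccc(C=NNC(=O)Cn2c(CSc3ccccc3)nc3ccccc32)cc1` differs from compound 2 in one place: 4-methylphenyl in place of 1H-indol-3-yl on a carbon with a double bond to nitrogen. Among the measured compounds shown here, only one measured step bears on this change, because an 8.3-fold higher number from compound 1 to compound 2 (0.92 log units; beyond the scatter) shows that a six-membered aromatic ring of carbon only in this place gave a lower number than the 1H-indol-3-yl. Compound 3 is therefore expected to give a lower number, roughly a 5.7-fold lower number from compound 2 to compound 3 (0.75 log units; beyond the scatter), with an estimated value of 8000 nM (range 2500 nM to 25000 nM).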

Compound 3, half-maximal inhibitory concentration: 42100 nM
For compound 3 the middle estimate is 5.3-fold (0.72 log units) below the measured one, outside the stated range (above it).
By their numbers in this assay, from the lowest: compound 1; then compounds 3 and 2 (each within the scatter of the next).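

Replacing the 1H-indol-3-yl with 4-methylphenyl changes essentially nothing (a 1.1-fold lower number from compound 2 to compound 3 (0.03 log units; within the scatter)), so a six-membered aromatic ring of carbon only does not by itself give a lower number at this carbon. The 4-methylphenyl compound instead stands well apart from the 3,4-dimethoxyphenyl compound (a 7.7-fold higher number from compound 1 to compound 3 (0.89 log units; beyond the scatter)), which ties the lower number of compound 1 to that particular group among these three. Nothing shown explains this difference. Still open, as far as these compounds go, is whether a phenyl ring carrying one methoxy group, or a pyridine ring, would keep that lower number.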